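A stereocentre inverted from compound 2

A few compounds are considered here, and "the series" means these few. Any claim that something is new, unique, unknown or untested is made for them only; others in the source may bear on it.

Measured in a functional assay on HCT-116 cells (Homo sapiens) for inhibition, read by MTT assay, with a stated time of 72 h; on this read-out lower numbers stand for stronger inhibition and higher numbers for weaker inhibition:
- compound 1 `CC1=NN(c2ccccc2)C(=O)[C@]12C(=O)C=CC[C@H]2c1ccc(C)cc1` gives 4220 nM
- compound 2 `CC1=NN(c2ccccc2)C(=O)[C@]12C(=O)C=CC[C@H]2c1cccc(C)c1` gives 9580 nM

Compound 2 holds the higher of these two numbers and is the weaker of the pair. Among the compounds with values here, its only measured neighbour is compound 1, and the modest step of a 2.3-fold higher number from compound 1 to compound 2 (0.36 log units; beyond the scatter) places 3-methylphenyl in place of 4-methylphenyl on a saturated ring carbon. Compound 3 `CC1=NN(c2ccccc2)C(=O)[C@]12C(=O)C=CC[C@@H]2c1cccc(C)c1` is unmeasured and differs from compound 2 as follows: the two compounds have the same atoms and bonds and differ only in configuration as drawn: 1 of 2 stereo elements differ; a stereocentre at a saturated ring carbon is drawn S in compound 2 and R in compound 3. Within the data shown here, no measured step changes a configuration, so the step of a 2.3-fold higher number from compound 1 to compound 2 (0.36 log units; beyond the scatter) indicates only a plausible scale. The data give no direction, so no step beyond the scatter is expected in this assay, though a modest move either way would not surprise. The expected change is a 1.0-fold higher number from compound 2 to compound 3 (0.02 log units; within the scatter). Compound 3 is estimated at 10000 nM, with an expected range of 3500 nM to 30000 nM.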

Compound 3, half-maximal inhibitory concentration: 5490 nM
Compound 3: middle estimate off by 1.8-fold (0.26 log units), on the high side, within the range that was stated.
By their numbers in this assay, from the lowest: compounds 1, 3 and 2 (each within the scatter of the next, the first and the last beyond it).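

Within the data shown here, the step of a 1.7-fold lower number from compound 2 to compound 3 (0.24 log units; within the scatter) in this assay is the only reading here of a change in configuration, and it adds something the move of the methyl group could not show. With 3-methylphenyl in the molecule, drawing this saturated ring carbon as R instead of S gives no change that this assay can separate from repeat scatter, so this stereocentre shows no measurable preference here. The comparison is a clean one, and the reading applies to this stereocentre alone: the fact that compounds 2 and 3 differ only in the configuration as drawn

Going by these compounds, whether the same holds with 4-methylphenyl remains open, as does the effect of the second stereo element, which is the same in compound 2 and compound 3. Also open, on these data alone, is how either configuration would read with a carboxylic acid or a dimethylamino group in place of the methyl group.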